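Dropping one methoxy from the cinnamoyl aryl of compound 3

This account rests on a few compounds, and the source may have more. Where it says the series, first, only, none or still open, it means among the compounds named here.

Three amides built on a trimethoxybenzoyl-substituted anilide core have been measured in a functional assay on HeLa cells (Homo sapiens) for cytotoxicity, read by MTT assay, with a stated time of 72 h; on this read-out lower numbers stand for stronger inhibition and higher numbers for weaker inhibition. Compound 1 `COc1cccc(/C=C/C(=O)Nc2cc(C(=O)c3cc(OC)c(OC)c(OC)c3)ccc2OC)c1` gives 3100 nM. For the measured compounds named here, compound 2 `COc1cc(/C=C/C(=O)Nc2cc(C(=O)c3cc(OC)c(OC)c(OC)c3)ccc2OC)ccc1F` gives 13600 nM; the only single-point step in this set, a 4.4-fold higher number from compound 1 to compound 2 (0.64 log units; beyond the scatter), is thus a weakening. Compound 3 `COc1ccc(/C=C/C(=O)Nc2cc(C(=O)c3cc(OC)c(OC)c(OC)c3)cc(OC)c2OC)cc1OC` gives 2700 nM, the lowest number of the three, though its gap to compound 1 lies within the scatter, so the two cannot be ordered; only compound 2 stands clearly apart from it.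

Compound 4 `COc1cccc(/C=C/C(=O)Nc2cc(C(=O)c3cc(OC)c(OC)c(OC)c3)cc(OC)c2OC)c1` is the next analog. From compound 3 to compound 4 the change is hydrogen in place of methoxy on an aromatic carbon. Going by the values given here, no measured step in this set follows that same change: the fluoro-for-hydrogen step from compound 1 to compound 2 concerns a different substituent on that ring, and compound 1 differs from compound 4 elsewhere in the core, so it can serve only as a loose reference. Among the compounds with values here, with no direct precedent, and with compounds 1 and 3 sitting close together, the expectation for compound 4 is a step of no clear size beyond the scatter, a 1.3-fold higher number from compound 3 to compound 4 (0.11 log units; within the scatter). Compound 4 is therefore estimated at 3500 nM, with a range from 1500 nM to 8500 nM.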

Compound 4, half-maximal inhibitory concentration: 6900 nM
Beside the measured number, compound 4's estimate is 2.0-fold (0.29 log units) below it; measured number inside the range.
By their numbers in this assay, from the lowest: compounds 3 and 1 (each within the scatter of the next); then compounds 4 and 2 (each within the scatter of the next).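

On the 3-methoxyphenyl arm, a methoxy on this carbon, ortho to a methoxy group and para to a large group, turns out to matter: going from 3,4-dimethoxyphenyl to 3-methoxyphenyl gives a 2.6-fold higher number from compound 3 to compound 4 (0.41 log units; beyond the scatter), a weakening beyond the scatter, and the first read of what removing a group from this ring costs. Compound 4 also shows that a methoxy added to the shared core brings no gain when the arm carries only the 3-methoxyphenyl group, since that change gives a 2.2-fold higher number from compound 1 to compound 4 (0.35 log units; beyond the scatter), again a modest weakening. So compound 4 stands on the weaker side of both its single-change neighbours, and no measurement at hand accounts for either step.

From the compounds shown here alone, what a hydroxyl or an amine on that same aromatic carbon would give remains open, as does the effect of an ethoxy group there. For the compounds shown here, also open is whether the methoxy on this carbon carries the same weight on the core of compound 1, where no single-change pair shows it.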